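The compounds below may be only part of what the source reports. "The series", "measured", "known", "first", "only" and "open" are said of these compounds alone.

Compound 1 `O=[N+]([O-])c1ccc(N/C(=N\O)c2cccc(F)c2)c2nonc12` is tested in an assay on tissue (MDA-MB-231 cells) for inhibition of Indoleamine 2,3-dioxygenase 1 (Homo sapiens), read by spectrophotometry, with stated times of 4 h and 5 h (on this read-out higher numbers stand for weaker inhibition and lower numbers for stronger inhibition), where compound 1 gives 245 nM. Its only measured companion, compound 2 `O=[N+]([O-])c1ccc(N/C(=N\O)c2ccc(F)cc2)c2nonc12`, gives 125 nM in this assay, and the step of a 2.0-fold lower number from compound 1 to compound 2 (0.29 log units; within the scatter) lies within the scatter, so the two stand together. Compound 3 `O=[N+]([O-])c1ccc(N/C(=N\O)c2ccc(F)c(Br)c2)c2nonc12` carries the change (3-bromo-4-fluorophenyl in place of 3-fluorophenyl on a carbon with a double bond to nitrogen). Going by the values given here, only the step from compound 1 to compound 2 bears on it, and it stayed within the scatter, so no step beyond the scatter is expected, with a slight lean toward the value of compound 2, as a 1.6-fold lower number from compound 1 to compound 3 (0.21 log units; within the scatter). Compound 3 is thus estimated at 150 nM in this assay, between 55 nM and 420 nM.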

Compound 3, half-maximal inhibitory concentration: 107 nM
Estimate against measurement, compound 3: 1.4-fold (0.15 log units) above; the measured number falls inside the stated range.
By their numbers in this assay, from the lowest: compounds 3, 2 and 1 (each within the scatter of the next, the first and the last beyond it).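

In this assay, going by these compounds alone, 3-bromo-4-fluorophenyl in place of 3-fluorophenyl gives the first step at this position that clears the scatter (a 2.3-fold lower number from compound 1 to compound 3 (0.36 log units; beyond the scatter)). Bromo in place of hydrogen on an aromatic carbon does not separate the pair that differs only by it (a 1.2-fold lower number from compound 2 to compound 3 (0.07 log units; within the scatter)), so compound 2 and compound 3 stand together. Nothing available explains either step.

The compounds shown leave open what 3-bromophenyl would give without the fluoro. They also leave open whether a phenyl carrying an amine or a carboxylic acid would be accepted on this carbon.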